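Taking the fluoro off compound 2

The source may report more compounds than this note shows. Statements on the series, on what has been measured and on what is new or still open speak of the compounds shown alone.

Compound 1 `O=c1oc2ccccc2c(=O)n1-c1ccc(Cl)cc1F` gives 7100 nM
Compound 2 `O=c1oc2ccc(F)cc2c(=O)n1-c1ccc(I)cc1F` gives 2050 nM

In a functional assay on RAW264.7 cells (Mus musculus) for inhibition, read by microscopy, with a stated time of 4 days, in the presence of a further agent that is not named here (a higher number here means a weaker inhibitor, a lower number a stronger inhibitor), compound 2 has the lower number of the two (2050 nM), and its gap to compound 1 (7100 nM) lies beyond the scatter. For the measured compounds named here, these two compounds differ in more than one place, and no measured pair shows a single change on its own.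

Compound 3 `O=c1oc2ccccc2c(=O)n1-c1ccc(I)cc1F` carries hydrogen in place of fluoro on an aromatic carbon, which gives it the same core as compound 1. A small rise in the number is expected, not beyond the scatter, since that core is so far known only from compound 1 at 7100 nM. The expected move is a 1.7-fold higher number from compound 2 to compound 3 (0.22 log units; within the scatter). For compound 3 the estimated value is 3400 nM, with an expected range of 1400 nM to 8000 nM.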

Compound 3, half-maximal inhibitory concentration: 4900 nM
For compound 3 the middle estimate is 1.4-fold (0.16 log units) below the measured one, within the range that was stated.
By their numbers in this assay, from the lowest: compound 2; then compounds 3 and 1 (each within the scatter of the next).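

In this assay, hydrogen in place of fluoro on an aromatic carbon of the fused system gives a 2.4-fold higher number from compound 2 to compound 3 (0.38 log units; beyond the scatter) as a modest step, and this is the first single change shown at this position. The iodo in place of chloro on an aromatic carbon gives a 1.4-fold lower number from compound 1 to compound 3 (0.16 log units; within the scatter) and so cannot be told from the scatter, which leaves the fluoro step as the only one of the two that lies beyond it. No measurement offered here bears on the reason for the fluoro step.

From the compounds shown here alone, whether the fluoro step holds with chloro in place of iodo remains open, since only the iodo pair shows it. So does what a methoxy group, an amine or a carboxylic acid would do at this position on the fused system.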